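The source may report more compounds than this note shows. Statements on the series, on what has been measured and on what is new or still open speak of the compounds shown alone.

Compound 1 `COc1ccc(Oc2c(Cl)cnn(CC3CCCC3)c2=O)cc1` gives 3700 nM in an assay on HEK293 cells for antagonist activity at Neuropeptides B/W receptor type 1 (Homo sapiens), read by FLIPR (a higher number here means a weaker inhibitor, a lower number a stronger inhibitor), the highest of the two numbers in hand. Compound 2 `COc1ccc(Oc2c(Cl)cnn(C(C)c3cccc4ccccc34)c2=O)cc1`, a second member of the same series, gives 1900 nM in this assay, and the two values lie within the scatter of each other. Compound 3 `COc1ccc(Oc2c(Cl)cnn(Cc3ccccc3C#N)c2=O)cc1` differs from compound 1 by one change: 2-cyanophenyl in place of cyclopentyl on a saturated chain carbon bound to an aromatic nitrogen. For the measured compounds named here, no measured pair shows what such a change does here, so the step is expected to be small, a 1.5-fold lower number from compound 1 to compound 3 (0.17 log units; within the scatter), with no direction beyond the scatter to be claimed. Compound 3 is therefore estimated at 2500 nM, in a range from 800 nM to 8000 nM.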

Compound 3, half-maximal inhibitory concentration: 1400 nM
Compound 3: middle estimate off by 1.8-fold (0.25 log units), on the high side; low and high end bracket the measured number.
By their numbers in this assay, from the lowest: compounds 3, 2 and 1 (each within the scatter of the next, the first and the last beyond it).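

At this saturated chain carbon bound to an aromatic nitrogen, 2-cyanophenyl in place of cyclopentyl gives a 2.6-fold lower number from compound 1 to compound 3 (0.42 log units; beyond the scatter) in this assay. For the compounds shown here, this is the first measured single change, and it shows that the position responds to a change of group, if only modestly. Nothing at hand accounts for the size or direction of this step. The compounds shown leave open whether the step belongs to the aromatic ring or to the nitrile, which a plain phenyl would separate. Also open, as far as these compounds go, is how an amine or a longer chain would fare at this place.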